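This account rests on a few compounds, and the source may have more. Where it says the series, first, only, none or still open, it means among the compounds named here.

The compounds measured in a functional assay on COLO 205 cells (Homo sapiens) for antiproliferative activity, with a stated time of 48 h (a lower number here means a stronger inhibitor of growth, a higher number a weaker inhibitor of growth), were:

compound 1, `Cc1cc(O)c(C2=NN(c3ccc(S(N)(=O)=O)cc3)C(c3ccccc3O)C2)cc1Cl`, 3540 nM
compound 2, `Cc1cc(O)c(C2=NN(c3ccc(S(N)(=O)=O)cc3)C(c3ccccc3Cl)C2)cc1Cl`, 3310 nM
compound 3, `Cc1cc(O)c(C2=NN(c3ccc(S(N)(=O)=O)cc3)C(/C=C/c3ccccc3)C2)cc1Cl`, 22100 nM

Compound 3 stands highest of the three numbers; its nearest neighbour is compound 1 and its furthest is compound 2, both beyond the scatter. Compound 4 is `COc1ccc(C2CC(c3cc(Cl)c(C)cc3O)=NN2c2ccc(S(N)(=O)=O)cc2)cc1OC`. The change from compound 3 to compound 4 is 3,4-dimethoxyphenyl in place of 2-phenylethenyl on a saturated ring carbon. Going by the values given here, two measured steps bear on this change, both running into compound 3: a 6.2-fold higher number from compound 1 to compound 3 (0.80 log units; beyond the scatter) and a 6.7-fold higher number from compound 2 to compound 3 (0.82 log units; beyond the scatter). In each, an aryl group on the saturated ring carbon gave a lower number than the 2-phenylethenyl group, and the two aryl-bearing compounds 1 and 2 sit close together, with a 1.1-fold lower number from compound 1 to compound 2 (0.03 log units; within the scatter). Among the compounds with values here, since compound 4 again carries an aryl group at this carbon, a step of similar size in the lowering direction is expected in this assay, a 5.8-fold lower number from compound 3 to compound 4 (0.76 log units; beyond the scatter), though no measured step tells how 3,4-dimethoxyphenyl compares with the aryl groups of compounds 1 and 2. Compound 4 is therefore estimated at 3800 nM, in a range from 1500 nM to 10000 nM.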

Compound 4, concentration for total growth inhibition: 3410 nM
For compound 4 the middle estimate is 1.1-fold (0.05 log units) above the measured one; the range from low to high includes it.
By their numbers in this assay, from the lowest: compounds 2, 4 and 1 (each within the scatter of the next); then compound 3.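

In this assay, 3,4-dimethoxyphenyl on the saturated ring carbon again stands clear of 2-phenylethenyl (a 6.5-fold lower number from compound 3 to compound 4 (0.81 log units; beyond the scatter)), so the gap seen with 2-hydroxyphenyl and 2-chlorophenyl also holds for an aryl group that carries neither hydroxy nor chloro. Compound 4 also sits level with both earlier aryl compounds (a 1.0-fold higher number from compound 2 to compound 4 (0.01 log units; within the scatter); a 1.0-fold lower number from compound 1 to compound 4 (0.02 log units; within the scatter)), and across compounds 1, 2 and 4 these three aryl groups stay within the scatter of one another despite their different substituents. Nothing at hand gives a reason for either the gap or the levelness.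

The compounds shown leave open whether the higher number of compound 3 goes with the double bond, which a saturated 2-phenylethyl chain at this carbon would test. They also leave open whether the carbon needs an aryl group at all, as a cyclohexyl group, an amine or a carboxylic acid there would show.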